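From 3-hydroxy-2-methylphenyl to 3-methylthiophen-2-yl in the series

The compounds below may be only part of what the source reports. "The series", "measured", "known", "first", "only" and "open" are said of these compounds alone.

In a functional assay on A549 cells (Homo sapiens) for cytotoxicity (a higher number here means a weaker inhibitor, a lower number a stronger inhibitor), compound 1 (`C=C/C=C\[C@H](C)[C@H](OC(N)=O)[C@@H](C)[C@H](O)[C@@H](C)C/C(C)=C\[C@H](C)[C@@H](O)[C@@H](C)/C=C\CCc1ccc(Oc2ccccc2)cc1`) gives 10000 nM. Among the measured compounds shown here, compound 2 (`C=C/C=C\[C@H](C)[C@H](OC(N)=O)[C@@H](C)[C@H](O)[C@@H](C)C/C(C)=C\[C@H](C)[C@@H](O)[C@@H](C)/C=C\CCc1cccc(O)c1C`) gives 910 nM, the lower of the two numbers so far, and its gap to compound 1 lies beyond the scatter.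

The next member is compound 3 (`C=C/C=C\[C@H](C)[C@H](OC(N)=O)[C@@H](C)[C@H](O)[C@@H](C)C/C(C)=C\[C@H](C)[C@@H](O)[C@@H](C)/C=C\CCc1sccc1C`), which keeps the shared core of compound 2 and alters only the end of the chain: 3-methylthiophen-2-yl in place of 3-hydroxy-2-methylphenyl on a saturated chain carbon, two bonds along the chain from a double-bonded chain carbon. The new group, 3-methylthiophen-2-yl, stands in place of 3-hydroxy-2-methylphenyl on a saturated chain carbon, two bonds along the chain from a double-bonded chain carbon.

For the measured compounds named here, no measured pair isolates this change. Going by the values given here, the only guide is the spread between compound 2 at 910 nM and compound 1 at 10000 nM, which shows how far apart numbers can sit. A moderately higher number in this assay, somewhat beyond the scatter, is expected, and the estimated move is a 2.7-fold higher number from compound 2 to compound 3 (0.44 log units; beyond the scatter). The estimate for compound 3 is 2500 nM, with an expected range of 800 nM to 8000 nM.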

Compound 3, half-maximal inhibitory concentration: 790 nM
Beside the measured number, compound 3's estimate is 3.2-fold (0.50 log units) above it; measured number below the stated range.
By their numbers in this assay, from the lowest: compounds 3 and 2 (each within the scatter of the next); then compound 1.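

In this assay, exchanging 3-hydroxy-2-methylphenyl for 3-methylthiophen-2-yl on a saturated chain carbon, two bonds along the chain from a double-bonded chain carbon, gives a 1.2-fold lower number from compound 2 to compound 3 (0.06 log units; within the scatter). Among the compounds shown here, this is the first one-place comparison, and at this position the read-out does not separate a six-membered aromatic ring of carbon only, with 1 hydrogen-bond donor, from a five-membered aromatic ring with 1 hetero atom and 0 hydrogen-bond donors. No measurement shown accounts for this outcome.

For the compounds shown here, the single step alters the ring and its substituents together, so the separate contributions of the hydroxyl, the methyl and the ring itself remain open. A plain phenyl, an unsubstituted thiophen-2-yl, or an amine in place of the hydroxyl would each address one of these parts, and a longer chain would test whether the result holds at a different distance from the double-bonded chain carbon.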